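A few compounds are considered here, and "the series" means these few. Any claim that something is new, unique, unknown or untested is made for them only; others in the source may bear on it.

Three compounds share one chain of two hydroxyl-bearing carbons linked through an ether bridge, and differ only in what sits on the aromatic nitrogen of the five-membered ring with three nitrogens. Compound 1 `CC1=C(CCCCCCCCCCn2cc(C[C@H](O)COCCOC[C@@H](O)Cc3ccc(-c4ccccc4)cc3)nn2)C(=O)c2ccccc2C1=O` and compound 2 `COC1=C(OC)C(=O)C(CCCCCCn2cc(C[C@H](O)COCCOC[C@@H](O)Cc3ccc(-c4ccccc4)cc3)nn2)=C(C)C1=O` carry a large group joined through a flexible chain; in a functional assay on HCT-116 cells (Homo sapiens) for inhibition, read by MTT assay, with a stated time of 72 h (on this read-out higher numbers stand for weaker inhibition of growth and lower numbers for stronger inhibition of growth), compound 1 gives 3000 nM, and compound 2 gives 5000 nM. Compound 3 `O[C@H](COCCOC[C@@H](O)Cc1cn(-c2cncnc2)nn1)Cc1ccc(-c2ccccc2)cc1` carries instead a pyrimidin-5-yl group directly on that nitrogen. In this assay compound 3 gives > 100000 nM, which is a limit of the assay and not a number. Compound 3 therefore stands at the limit of > 100000 nM in this assay, at which 1 of the 3 values shown sits, the weak end of everything shown.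

Compound 4 `O=c1[nH]c2ccc(-n3cc(C[C@H](O)COCCOC[C@@H](O)Cc4ccc(-c5ccccc5)cc4)nn3)cc2s1` arises from compound 3 by the change (a group of 10 heavy atoms (7 carbon, 1 nitrogen, 1 oxygen, 1 sulfur; one five-membered aromatic ring with 2 hetero atoms, one six-membered aromatic ring of carbon only) in place of a group of 6 heavy atoms (4 carbon, 2 nitrogen; one six-membered aromatic ring with 2 hetero atoms), on an aromatic nitrogen). Within the data shown here, no measured pair isolates this kind of change, and the only compounds with numbers, compound 1 and compound 2, differ from compound 4 in several places at once. The expectation is a small gain at best, so the step from compound 3 to compound 4 is estimated as an at least 1.2-fold lower number from compound 3 to compound 4 (0.09 log units; that floor lies within the scatter), with a real chance that only a limit is reported again. Compound 4 is expected to give about 80000 nM, within a range of 20000 nM to 200000 nM.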

Compound 4, concentration for 50% growth inhibition: 9200 nM
Compound 4: middle estimate off by 8.7-fold (0.94 log units), on the high side, and the stated range ends above it.
By their numbers in this assay, from the lowest: compounds 1, 2 and 4 (each within the scatter of the next, the first and the last beyond it). At a limit, above all of these: compound 3.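

On the aromatic nitrogen of the five-membered aromatic ring, the group of 10 heavy atoms replaces pyrimidin-5-yl with the rest of the molecule unchanged, and this assay shows an at least 10-fold lower number from compound 3 to compound 4 (1.03 log units; beyond the scatter). Among these compounds, the earlier compounds offered no such single change, so this is the first sign that the read-out responds to the group at this position. The value of compound 3 is a limit and not a number, so the step has only a lower bound: the limit of > 100000 nM in this assay, at which 1 of the 4 values shown sits.

The compounds shown do not tell which part of the entering group matters, as the second ring, the double bond outside aromatic rings and the hydrogen-bond donor all enter together. From the compounds shown here alone, how a plain phenyl ring, or a ring carrying an amine or a carboxylic acid, would read on this nitrogen also remains open.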